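The compounds below may be only part of what the source reports. "The series", "measured", "known", "first", "only" and "open" are said of these compounds alone.

Measured compounds:
- compound 1, `O=C(C1CCCCC1)N1CCC(C(=O)N2N=CCC2c2ccccc2)CC1`: 5.4
- compound 2, `C[C@@H]1C=NN(C(=O)C(C)(C)C)[C@@H]1c1ccccc1`: 6.5

In a physicochemical assay for lipophilicity, read by HPLC, measured as chromatographic lipophilicity, at pH 7.4 (on this read-out higher numbers stand for higher lipophilicity and lower numbers for lower lipophilicity), compound 1 gives 5.4, the lower of the two numbers measured; compound 2 gives 6.5, which lies above it by more than the scatter. For the measured compounds named here, no pair of measured compounds differs in one place only, so no measured step is available to lean on.

Compound 3, `O=C(C1CCN(C(=O)C(F)(F)F)CC1)N1N=CCC1c1ccccc1`, is to be measured in this assay. It differs from compound 1 in one place: trifluoromethyl in place of cyclohexyl on a carbonyl carbon. With only the two measured values as a frame, the step from compound 1 to compound 3 is expected to be downward and to exceed the scatter, at about a number 1.30 log units lower from compound 1 to compound 3 (beyond the scatter). Compound 3 is therefore estimated at 4.1, with a likely range from 3.4 to 4.8.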

Compound 3, distribution coefficient: 4.9
For compound 3 the middle estimate is 0.80 log units below the measured one, outside the stated range (above it).
By their numbers in this assay, from the lowest: compound 3; then compound 1; then compound 2.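

In this assay the change gives the first single-place step available in this series, a number 0.50 log units lower from compound 1 to compound 3 (beyond the scatter) with the shared core left untouched. It shows that the read-out responds to the group on this carbonyl carbon, whose other neighbours are an amide-type nitrogen in a ring, even though neither cyclohexyl nor trifluoromethyl counts any hydrogen-bond donors or acceptors. No measured evidence accounts for the size or direction of this step.

This single pair cannot separate the loss of the carbon ring from the entry of the fluorine atoms, since both happen in the same change. The compounds shown also leave open where a methyl group or a morpholine ring on this carbonyl carbon would fall relative to compound 1 and compound 3.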